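A few compounds are considered here, and "the series" means these few. Any claim that something is new, unique, unknown or untested is made for them only; others in the source may bear on it.

Working notes on the series, two compounds measured so far. In a functional assay on MKN-45 cells (Homo sapiens) for cytotoxicity (a lower number here means a stronger inhibitor, a higher number a weaker inhibitor), compound 1 (`COc1ccc(S(=O)(=O)N2CCc3cccc(NS(=O)(=O)c4ccc(F)cc4)c32)cc1`) gives 890 nM and compound 2 (`COc1ccc(S(=O)(=O)N2CCc3cccc(NC(=O)c4ccc([N+](=O)[O-])cc4)c32)cc1`) gives 95 nM. Compound 2 therefore holds the lower number of the pair, and the gap lies beyond the usual scatter. The next compound is compound 3 (`COc1ccc(S(=O)(=O)N2CCc3cccc(NC(=O)c4ccco4)c32)cc1`), which keeps the shared core and the carbonyl of compound 2 and carries furan-2-yl in place of 4-nitrophenyl on a carbonyl carbon. For the measured compounds named here, no measured step covers this change, so the expectation in this assay is anchored only on compound 2 at 95 nM, and the range is kept wide. Expected here is a 1.4-fold lower number from compound 2 to compound 3 (0.13 log units; within the scatter), which would be no step beyond the scatter. For compound 3 the estimated value is 70 nM, with an expected range of 15 nM to 300 nM.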

Compound 3, half-maximal inhibitory concentration: 10.7 nM
Compound 3: the middle estimate sits 6.5-fold (0.82 log units) above what was measured, outside the stated range (below it).
By their numbers in this assay, from the lowest: compound 3; then compound 2; then compound 1.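

In this assay, furan-2-yl in place of 4-nitrophenyl on a carbonyl carbon gives an 8.9-fold lower number from compound 2 to compound 3 (0.95 log units; beyond the scatter) and shows that the group on this carbonyl carbon alone can move the number beyond the scatter, and that 4-nitrophenyl is not needed for a low number. Exchanging the whole group on the nitrogen, with (furan-2-yl)carbonyl in place of (4-fluorophenyl)sulfonyl on a nitrogen on an aromatic ring, gives an 83-fold lower number from compound 1 to compound 3 (1.92 log units; beyond the scatter) and is the larger of the two new steps. Nothing available here bears on the reason for either step.

The compounds shown leave open whether the gain follows the ring oxygen of furan-2-yl or the five-membered ring itself, which thiophen-2-yl or unsubstituted phenyl on the same carbonyl carbon would separate. Also open, on these data alone, is whether an aromatic ring is needed there at all, as against a saturated ring such as tetrahydrofuran-2-yl.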